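Piperidin-1-yl in place of pyrrolidin-1-yl: series notes

The source may report more compounds than this note shows. Statements on the series, on what has been measured and on what is new or still open speak of the compounds shown alone.

Measured in a physicochemical assay for lipophilicity, read by HPLC, measured as octanol-water partition; a lower number here means a more polar compound, a higher number a more lipophilic compound:
Compound 1 `CN(C)C1=NN(c2ccccc2)CN(c2ccccc2Cl)C1=O` gives 3.6
Compound 2 `O=C1C(N2CCCCC2)=NN(c2ccc(Cl)cc2)CN1c1ccccc1Cl` gives 5
Compound 3 `O=C1C(N2CCCC2)=NN(c2ccccc2)CN1c1ccccc1Cl` gives 4

In this assay compound 3, at 4, stands second highest of the three numbers, with compound 1 lower and compound 2 higher, both gaps beyond the scatter.

Among the measured compounds shown here, compound 4 `O=C1C(N2CCCCC2)=NN(c2ccccc2)CN1c1ccccc1Cl` has no measurement yet. The structural change is piperidin-1-yl in place of pyrrolidin-1-yl on a carbon with a double bond to nitrogen, with the rest of the structure unchanged.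

For the measured compounds named here, only one measured step changes this same place: a number 0.40 log units higher from compound 1 to compound 3 (beyond the scatter), with pyrrolidin-1-yl in place of dimethylamino. Going by the values given here, compound 2 is higher than compound 3 on the values alone, but no single-place step connects the two, so it gives no size for this change.

On the strength of the step to compound 3, a modest rise of similar size is expected in this assay, which may not clear the scatter by much. The expected change is a number 0.40 log units higher from compound 3 to compound 4 (beyond the scatter). For compound 4 the estimate is 4.4, with an expected range from 4.1 to 4.8.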

Compound 4, partition coefficient: 4.6
Estimate against measurement, compound 4: 0.20 log units below; the measured number falls inside the stated range.
By their numbers in this assay, from the lowest: compound 1; then compound 3; then compound 4; then compound 2.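

Working notes: on a carbon with a double bond to nitrogen, this assay now gives a second step in the same direction, a number 0.60 log units higher from compound 3 to compound 4 (beyond the scatter), which extends the earlier a number 0.40 log units higher from compound 1 to compound 3 (beyond the scatter) and adds up to a number 1.00 log units higher from compound 1 to compound 4 (beyond the scatter) across dimethylamino, pyrrolidin-1-yl and piperidin-1-yl, with none of these three compounds going against the rise. Among the compounds shown here, compound 4 also gives the first size for a change in a second place. It ties compound 2 into the series through hydrogen in place of chloro on an aromatic carbon, a number 0.40 log units lower from compound 2 to compound 4 (beyond the scatter), a step that so far rests on this single pair. No supporting information on the origin of either change is available.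

The three amines at the first position leave open whether the rise continues with a seven-membered azepan-1-yl ring or a diethylamino group, and whether a morpholin-4-yl ring, with oxygen in the ring, follows the same direction. As far as these compounds go, the chloro step is also known only with piperidin-1-yl in place, so its size alongside pyrrolidin-1-yl or dimethylamino remains open.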